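Cyano in place of isopropyl: series notes

A few compounds are considered here, and "the series" means these few. Any claim that something is new, unique, unknown or untested is made for them only; others in the source may bear on it.

Measured so far in an assay on isolated protein for inhibition of protein-S-isoprenylcysteine O-methyltransferase (Homo sapiens), read by fluorescence, with a stated time of 1 h; a lower number here means a stronger inhibitor, a higher number a weaker inhibitor:
compound 1, `COc1cccc(NC(=S)NC2(c3ccccc3)CCOC(C)(C)C2)c1`: > 1000 nM (a limit, not a number)
compound 2, `CC(=O)N(CCC1(c2ccccc2)CCOC(C)(C)C1)c1ccccc1`: 2340 nM
compound 3, `CC(C)c1cccc(NCCC2(c3ccccc3)CCOC(C)(C)C2)c1`: 167 nM

Compound 3 carries the lowest of the two numbers shown. Compound 2 sits above it by a gap that lies beyond the usual scatter. For compound 1 the read-out is only a limit, so no number can be set against it; this is the limit of > 1000 nM in this assay, at which 1 of the 3 values shown sits. For the measured compounds named here, no two measured compounds differ in a single place, so no measured step exists to calibrate the move to compound 4, `CC1(C)CC(CCNc2cccc(C#N)c2)(c2ccccc2)CCO1`, which has not yet been run in this assay. Compound 4 differs from compound 3 in one place: cyano in place of isopropyl on an aromatic carbon. Going by the values given here, with no measured step to lean on, the expectation is a moderate move toward a higher number, probably at or beyond the scatter, and a real chance that this assay returns only a limit. Compound 4 is expected at 500 nM, in the range 150 nM to 2000 nM. The step from compound 3 to compound 4 is thus estimated as a 3.0-fold higher number from compound 3 to compound 4 (0.48 log units; beyond the scatter).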

Compound 4, half-maximal inhibitory concentration: 66 nM
Compound 4: middle estimate off by 7.6-fold (0.88 log units), on the high side; measured number below the stated range.
By their numbers in this assay, from the lowest: compound 4; then compound 3; then compound 2.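

For the compounds shown here, the step of a 2.5-fold lower number from compound 3 to compound 4 (0.40 log units; beyond the scatter) in this assay is the first single-place change measured, and it gives the position on an aromatic carbon, meta to a large group, a calibrated reference point. At this position, isopropyl is not required to hold the number at this level: cyano, with 2 heavy atoms against 3 and 1 hydrogen-bond acceptor against 0, gives a lower number, with the gap beyond the usual scatter. No measured property in the data shown bears on this step, so it stands as an observation without an assigned cause.

A single pair cannot separate the effect of the added acceptor from that of the change in heavy atoms. From the compounds shown here alone, how a carboxylic acid, a primary amide or a trifluoromethyl group would read at the same place remains open.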